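This account rests on a few compounds, and the source may have more. Where it says the series, first, only, none or still open, it means among the compounds named here.

Measured in a functional assay on MIA PaCa-2 cells (Homo sapiens) for inhibition, read by MTT assay, with a stated time of 72 h; on this read-out higher numbers stand for weaker inhibition and lower numbers for stronger inhibition:
compound 1 `Cc1cnc(C(=O)Nc2cc(F)cc3cccnc23)cn1` gives 310 nM
compound 2 `Cc1cnc(C(=O)Nc2cc(OCCNC(=O)OC(C)(C)C)cc3cccnc23)cn1` gives 670 nM

Of the two numbers in this assay, compound 2 holds the higher one; its nearest neighbour is compound 1, whose number is lower by a margin that lies beyond the usual scatter of this kind of measurement. Both compounds share the same core, and they differ at one ring position, where compound 1 carries a fluorine and compound 2 a chain ending in a protected amine.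

Compound 3 `Cc1cnc(C(=O)Nc2cc(OCCC3CCNCC3)cc3cccnc23)cn1` has not yet been measured in this assay. It departs from compound 2 in a single place: piperidin-4-yl in place of (tert-butoxycarbonyl)amino on a saturated chain carbon, two bonds along the chain from an oxygen on an aromatic ring. The chain and its attachment to the aromatic oxygen stay as they are; only the group at the far end of the chain is exchanged.

For the measured compounds named here, no step between two measured compounds mirrors this exchange, so the expectation rests on the range that compound 1 and compound 2 set. The author expects compound 3 to give a somewhat lower number than compound 2 in this assay, a step of a 1.7-fold lower number from compound 2 to compound 3 (0.22 log units; within the scatter), which is modest and close to the scatter. The estimate for compound 3 is 400 nM, with a range from 150 nM to 1100 nM.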

Compound 3, half-maximal inhibitory concentration: 6170 nM
Estimate against measurement, compound 3: 15-fold (1.19 log units) below, outside the stated range (above it).
By their numbers in this assay, from the lowest: compound 1; then compound 2; then compound 3.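

In this assay, placing piperidin-4-yl instead of (tert-butoxycarbonyl)amino at the far end of the chain gives a 9.2-fold higher number from compound 2 to compound 3 (0.96 log units; beyond the scatter) and so shows that this position is sensitive to the group the chain carries. Compound 1 and compound 2 alone had not shown this, since their printed values lie much closer together than either does to the value of compound 3; measured against the fluoro of compound 1, 2-(piperidin-4-yl)ethoxy on the same aromatic carbon gives a 20-fold higher number from compound 1 to compound 3 (1.30 log units; beyond the scatter) and marks the largest step in this small set. Nothing among the data shown accounts for the weaker inhibition.

The exchange replaces the whole end group at once, so the compounds shown leave open whether the change in number follows the saturated ring or its ring nitrogen, a question that a chain ending in a morpholine, an N-methylpiperidine or a free primary amine could help to separate. They also leave open how the number would respond to a shorter or longer chain carrying the same piperidin-4-yl group.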